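A Bromine-Bearing Furan Replaces a Pyrrole: What to Expect

This account rests on a few compounds, and the source may have more. Where it says the series, first, only, none or still open, it means among the compounds named here.

Of the compounds shown here, three have been measured in a functional assay on MCF7 cells (Homo sapiens) for inhibition, read by MTT assay, with a stated time of 72 h; a lower number here means a stronger inhibitor of growth, a higher number a weaker inhibitor of growth. Compound 1 `N#C/C(=C\c1ccc([N+](=O)[O-])cc1)C(=O)c1c[nH]c2ccccc12` gives 35000 nM, compound 2 `COc1ccc(CNC(=O)/C(C#N)=C/c2ccc[nH]2)cc1` gives 34000 nM, and compound 3 `N#C/C(=C\c1ccco1)C(=O)NCc1ccc(Cl)c(Cl)c1` gives 20000 nM. Compound 2 stands second highest of the three, but its gaps to compound 1 and to compound 3 both lie within the usual scatter, so no order can be read among them. Compound 4 `COc1ccc(CNC(=O)/C(C#N)=C/c2ccc(Br)o2)cc1` is not yet measured; it differs from compound 2 by 5-bromofuran-2-yl in place of 1H-pyrrol-2-yl on a double-bonded chain carbon bound to a double-bonded chain carbon. Among the compounds with values here, no measured pair shows this exact change, so only the values themselves guide the expectation. The step from compound 2 to compound 4 is expected to be a modest move toward a lower number, a 1.5-fold lower number from compound 2 to compound 4 (0.19 log units; within the scatter), staying within the scatter. Compound 4 is therefore estimated at 22000 nM, with a range from 8000 nM to 60000 nM.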

Compound 4, concentration for 50% growth inhibition: 11000 nM
Compound 4: the middle estimate sits 2.0-fold (0.30 log units) above what was measured; measured number inside the range.
By their numbers in this assay, from the lowest: compounds 4, 3, 2 and 1 (each within the scatter of the next, the first and the last beyond it).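

In this assay, the place on a double-bonded chain carbon bound to a double-bonded chain carbon now shows a response to a change of ring: 5-bromofuran-2-yl in place of 1H-pyrrol-2-yl gives a 3.1-fold lower number from compound 2 to compound 4 (0.49 log units; beyond the scatter), the first difference here that stands clear of the scatter. The swap brings in the furan oxygen and the bromine together, and it removes the pyrrole nitrogen with its hydrogen, so the step belongs to the whole group. No measurement here explains the step.

On these data alone, how much of it comes from the bromine and how much from the furan stays open. So does whether a plain furan-2-yl, or a chlorine, a methyl or an amine in place of the bromine, would give a similar number.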